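The source may report more compounds than this note shows. Statements on the series, on what has been measured and on what is new or still open speak of the compounds shown alone.

Compound 1 `O=C(O)c1ccc(C(=O)/C(=C\c2ccc(Cl)c([N+](=O)[O-])c2)SCc2ccc(Cl)cc2)cc1`: 1000 nM
Compound 2 `Cc1ccc(S/C(=C/c2c[nH]c3ccc(Cl)cc23)C(=O)c2ccc(Br)cc2)cc1`: 1000 nM
Compound 3 `O=C(O)c1ccc(C(=O)/C(=C\c2ccc(Cl)c([N+](=O)[O-])c2)SCc2ccc(Br)cc2)cc1`: 500 nM

All three were tested in a functional assay on DU-145 cells (Homo sapiens) for inhibition, read by trypan blue exclusion, with a stated time of 96 h; a lower number here means a stronger inhibitor of growth, a higher number a weaker inhibitor of growth. Compound 3 differs from compound 1 only by bromo in place of chloro on an aromatic carbon, and that step, a 2.0-fold lower number from compound 1 to compound 3 (0.30 log units; within the scatter), stays within the scatter. The core of compound 2 differs from that of compound 1 in a way that is not broken down here; in this assay compound 2 gives 1000 nM.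

Compound 4 `Cc1ccc(S/C(=C/c2c[nH]c3ccc(Br)cc23)C(=O)c2ccc(Br)cc2)cc1` has not yet been measured. It differs from compound 2 by bromo in place of chloro on an aromatic carbon. This is the same kind of change as from compound 1 to compound 3, but not the same: in compound 3 the carbon is para to a large group, whereas in compound 4 it lies in a ring that is part of a fused or bridged system of two rings, meta to a fused ring and para to a fused ring.

Because the earlier step of a 2.0-fold lower number from compound 1 to compound 3 (0.30 log units; within the scatter) was small, a similarly small step is expected from compound 2 to compound 4, a 1.4-fold lower number from compound 2 to compound 4 (0.15 log units; within the scatter). Compound 4 is therefore estimated to give about 700 nM in this assay, most likely between 300 nM and 1500 nM.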

Compound 4, concentration for 50% growth inhibition: 1000 nM
Estimate against measurement, compound 4: 1.4-fold (0.15 log units) below; measured number inside the range.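

In this assay, bromo in place of chloro on an aromatic carbon gives no change at the digits printed from compound 2 to compound 4 (within the scatter). Set beside the earlier case, the two cores cannot be told apart for this change: the same change on two cores in this assay, a 2.0-fold lower number (0.30 log units; within the scatter) from compound 1 to compound 3 and no change at the digits printed (within the scatter) from compound 2 to compound 4, 2.0-fold (0.30 log units) apart, within the scatter of two such steps. Among these compounds, this shows that the swap stays small on both cores, but it rests on only two pairs, with the swapped carbon in a different place in each, so it does not show that the two halogens are interchangeable throughout the series.

The compounds shown leave open what a clearly different group on these carbons, such as fluoro, methoxy or an amine, would do. They also leave open whether any replacement there can move the number beyond the scatter.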